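Methyl to Methoxy on the Pendant Phenyl Ring

The source may report more compounds than this note shows. Statements on the series, on what has been measured and on what is new or still open speak of the compounds shown alone.

Compound 1, `CC(C)n1ncc2c(C(=O)NCc3cn(-c4ccccc4)nn3)cccc21`, in a functional assay on MGC-803 cells (Homo sapiens) for inhibition, read by MTT assay, with a stated time of 72 h; on this read-out lower numbers stand for stronger inhibition and higher numbers for weaker inhibition: > 40000 nM, a limit of the assay.
Compound 2, `Cc1ccccc1-n1cc(CNC(=O)c2cccc3c2cnn3C(C)C)nn1`, in this assay: > 40000 nM, likewise a limit of the assay.

Compound 2 therefore stands at the limit, with no number of its own; (the limit of > 40000 nM in this assay, at which 2 of the 2 values shown sit). Within the data shown here, the one measured step, a step that the two limits leave unreadable from compound 1 to compound 2, has two limits as its ends and cannot be read. Compound 3, `COc1ccc(-n2cc(CNC(=O)c3cccc4c3cnn4C(C)C)nn2)cc1`, differs from compound 2 by 4-methoxyphenyl in place of 2-methylphenyl on an aromatic nitrogen. Among the measured compounds shown here, no measured step in this small set touches that change, and the only step recorded stays unreadable, so nothing supports an expectation of a move beyond the scatter in either direction. The expected step of a number no higher from compound 2 to compound 3 (the limit leaves the size open) is set at no change. Compound 3 is estimated at 40000 nM, with a range from 20000 nM to 80000 nM, and most likely reported once more as a limit in this assay.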

Compound 3, half-maximal inhibitory concentration: > 40000 nM
Compound 3 ended at the assay's limit; the forecaster's own chance of this, stated with the estimate: 85%; the middle value lies on the limit itself.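

Among these compounds, compound 1, compound 2 and compound 3 all stand at a limit in this assay, so no step among them can be read: the limit of > 40000 nM in this assay, at which 3 of the 3 values shown sit. The compounds shown leave open whether any group on the aromatic nitrogen would give a measured number rather than a limit.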